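Notes: 5-methylthiophen-2-yl in place of 3-methylthiophen-2-yl

This account rests on a few compounds, and the source may have more. Where it says the series, first, only, none or still open, it means among the compounds named here.

- compound 1 `Cc1ccc(/C=C(\C(=O)c2ccc(Cl)cc2)S(=O)(=O)Cc2ccc(F)cc2)s1` gives 50000 nM
- compound 2 `Cc1ccc(CS(=O)(=O)/C(=C/c2ccc(N(C)C)cc2)C(=O)c2ccc(Cl)cc2)cc1` gives 50000 nM
- compound 3 `Cc1ccc(CS(=O)(=O)/C(=C/c2sccc2C)C(=O)c2ccc(Cl)cc2)cc1` gives 25000 nM

In a functional assay on DU-145 cells (Homo sapiens) for inhibition, read by trypan blue exclusion, with a stated time of 96 h (on this read-out higher numbers stand for weaker inhibition of growth and lower numbers for stronger inhibition of growth), compound 3 gives 25000 nM and lies within the scatter of both compound 1 and compound 2, so the three values do not separate. Compound 4 `Cc1ccc(CS(=O)(=O)/C(=C/c2ccc(C)s2)C(=O)c2ccc(Cl)cc2)cc1` has the same atoms as compound 3, joined differently, with 5-methylthiophen-2-yl in place of 3-methylthiophen-2-yl on a double-bonded chain carbon bound to a double-bonded chain carbon and nothing else altered. Within the data shown here, the one measured step at this place is a 2.0-fold lower number from compound 2 to compound 3 (0.30 log units; within the scatter), which replaces 4-(dimethylamino)phenyl with 3-methylthiophen-2-yl and stays within the scatter. Compound 1 already carries 5-methylthiophen-2-yl and gives 50000 nM, but the rest of its structure differs from that of compound 4, so no direct measure of this swap exists. In this assay the estimate is therefore a 1.2-fold higher number from compound 3 to compound 4 (0.08 log units; within the scatter), and no change in either direction is expected beyond the scatter. Compound 4 is estimated at 30000 nM, with an expected range of 10000 nM to 60000 nM for the measurement.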

Compound 4, concentration for 50% growth inhibition: 25000 nM
Estimate against measurement, compound 4: 1.2-fold (0.08 log units) above, and the stated range covers the measured number.
By their numbers in this assay, from the lowest: compounds 3, 4, 1 and 2 (each within the scatter of the next).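

In this assay, among these compounds, 5-methylthiophen-2-yl in place of 3-methylthiophen-2-yl on a double-bonded chain carbon bound to a double-bonded chain carbon gives no change at the digits printed from compound 3 to compound 4 (within the scatter) and supplies the direct read of this swap that the earlier compounds lacked. At the same place, 5-methylthiophen-2-yl in place of 4-(dimethylamino)phenyl gives a 2.0-fold lower number from compound 2 to compound 4 (0.30 log units; within the scatter) and methyl in place of fluoro on an aromatic carbon gives a 2.0-fold lower number from compound 1 to compound 4 (0.30 log units; within the scatter) in the same assay, so neither change separates the compounds. No supporting data bear on this result.

With all four compounds within the scatter of one another, the shown changes give no structure-activity trend at either place. Still open, as far as these compounds go, is whether a thiophen-2-yl carrying a carboxylic acid or an amine at this place would move the number beyond the scatter.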